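A few compounds are considered here, and "the series" means these few. Any claim that something is new, unique, unknown or untested is made for them only; others in the source may bear on it.

Series notes. Compound 1 `CCc1oc2ccc(OC)cc2c1C(=O)c1ccc(OC)cc1` carries two aryl methyl ethers; compound 2 `CCc1oc2ccc(OC)cc2c1C(=O)c1ccc(O)cc1` and compound 3 `CCc1oc2ccc(O)cc2c1C(=O)c1ccc(OC)cc1` each strip one of them back to a hydroxy. In an assay for inhibition of solute carrier family 22 member 12 (Homo sapiens), read by scintillation counting, with a stated time of 60 min, tested at 50 uM (a lower number here means less inhibition, a higher number more inhibition at the concentration tested (going by the name of the read-out)), compound 1 gives 24.3%, compound 2 gives 92.7%, and compound 3 gives 12.9%. Compound 3 thus stands lowest of the three measured compounds, with compound 1 nearest above it and compound 2 furthest above it. The two measured steps are a number 68.4 percentage points higher from compound 1 to compound 2 (beyond the scatter) and a number 11.4 percentage points lower from compound 1 to compound 3 (beyond the scatter), so the same kind of change lands very differently in the two places it has been tried.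

Compound 4 `CCc1oc2ccc(O)cc2c1C(=O)c1ccc(O)cc1` is not yet measured. It differs from compound 3 by hydrogen in place of methyl on an oxygen on an aromatic ring, methoxy to hydroxy. The step of a number 68.4 percentage points higher from compound 1 to compound 2 (beyond the scatter) bears directly on this, being the same change made in the same place, and it was large and upward; the step of a number 11.4 percentage points lower from compound 1 to compound 3 (beyond the scatter) merely fixes the lower starting point of compound 3. A large upward step is therefore expected, estimated as roughly a number 67.1 percentage points higher from compound 3 to compound 4 (beyond the scatter). For compound 4 the expected value in this assay is 80%, with a range from 55% to 95%.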

Compound 4, a percentage reported as inhibition, at one concentration (the size of the read-out at that concentration, not a potency): 96.5%
The estimate for compound 4 lay 16.5 percentage points below the measured number; the measured number lies above the stated range.
By their numbers in this assay, from the lowest: compound 3; then compound 1; then compounds 2 and 4 (each within the scatter of the next).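

In this assay, for the compounds shown here, methoxy to hydroxy at the place first changed in compound 2 again gives a large rise on a second core, a number 83.6 percentage points higher from compound 3 to compound 4 (beyond the scatter), though the size of the step depends on the core: the same change on two cores in this assay, a number 68.4 percentage points higher (beyond the scatter) from compound 1 to compound 2 and a number 83.6 percentage points higher (beyond the scatter) from compound 3 to compound 4, 15.2 percentage points apart, beyond the scatter of two such steps At the other methoxy, the same change gives a number 3.8 percentage points higher from compound 2 to compound 4 (within the scatter), so the fall seen on the core with two methyl ethers does not carry over to the core that already holds the hydroxy: the same change on two cores in this assay, a number 11.4 percentage points lower (beyond the scatter) from compound 1 to compound 3 and a number 3.8 percentage points higher (within the scatter) from compound 2 to compound 4, 15.2 percentage points apart, beyond the scatter of two such steps Across the four compounds, the two with that hydroxy, compound 2 and compound 4, both read high, the two with methoxy there read low, and no compound goes against this.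

A single concentration cannot separate compound 2 from compound 4 in potency. As far as these compounds go, whether a carboxylic acid could stand in place of that hydroxy, or a longer chain in place of the ethyl, remains open.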